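Thiophen-3-yl to methylpyrazolyl on the amide carbonyl

This account rests on a few compounds, and the source may have more. Where it says the series, first, only, none or still open, it means among the compounds named here.

Three amides on the shared core have been measured in a functional assay on KM12 cells (Homo sapiens) for inhibition, read by colorimetric assay and sulforhodamine B assay, with a stated time of 48 h; on this read-out higher numbers stand for weaker inhibition of growth and lower numbers for stronger inhibition of growth. Compound 1 `CCCCCCCCCCCC[C@@H](O)[C@H]1CC[C@H]([C@H](O)CCCCCCCCCCNC(=O)c2ccoc2)O1` gives 100000 nM. Compound 2 `CCCCCCCCCCCC[C@@H](O)[C@H]1CC[C@H]([C@H](O)CCCCCCCCCCNC(=O)c2cncs2)O1` gives 100000 nM. Compound 3 `CCCCCCCCCCCC[C@@H](O)[C@H]1CC[C@H]([C@H](O)CCCCCCCCCCNC(=O)c2ccsc2)O1` gives 3020 nM, the lowest of the three numbers.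

The next change leads to compound 4 `CCCCCCCCCCCC[C@@H](O)[C@H]1CC[C@H]([C@H](O)CCCCCCCCCCNC(=O)c2ccnn2C)O1`, with 1-methyl-1H-pyrazol-5-yl in place of thiophen-3-yl on a carbonyl carbon.

Among the measured compounds shown here, no measured compound carries this ring, so the evidence is indirect. Two large steps bear on it, a 33-fold lower number from compound 1 to compound 3 (1.52 log units; beyond the scatter) and a 33-fold lower number from compound 2 to compound 3 (1.52 log units; beyond the scatter), both beyond the scatter. Against these, no change at the digits printed from compound 1 to compound 2 (within the scatter) shows that the two other rings do not separate. Both measured replacements of thiophen-3-yl therefore sit at a much higher number, and a move in that direction is expected here too, perhaps less complete. The estimated step is a 9.9-fold higher number from compound 3 to compound 4 (1.00 log units; beyond the scatter), towards weaker inhibition of growth. For compound 4 the expected value is 30000 nM, with an estimated range of 5000 nM to 100000 nM.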

Compound 4, concentration for 50% growth inhibition: 100000 nM
For compound 4 the middle estimate is 3.3-fold (0.52 log units) below the measured one, within the range that was stated.
By their numbers in this assay, from the lowest: compound 3; then compounds 1, 2 and 4 (each within the scatter of the next).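

In this assay there is a 33-fold higher number from compound 3 to compound 4 (1.52 log units; beyond the scatter), which makes 1-methyl-1H-pyrazol-5-yl a third replacement of thiophen-3-yl on this carbonyl carbon to end at a much higher number, leaving compound 3 alone among the four amides at a low one. The new ring does not separate from the other two replacements, with no change at the digits printed from compound 2 to compound 4 (within the scatter) and no change at the digits printed from compound 1 to compound 4 (within the scatter), so the sensitivity of this position rests on a single ring, and compound 3 is the only amide here that stands apart. Nothing measured on these compounds bears on why thiophen-3-yl differs from the other three rings.

Still open, as far as these compounds go, is what a phenyl ring or thiophen-2-yl would give on the same carbonyl carbon. Also open, from the compounds shown here alone, is whether the thiophen-3-yl amide keeps its lower number when a shorter chain links it to the shared core.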